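A few compounds are considered here, and "the series" means these few. Any claim that something is new, unique, unknown or untested is made for them only; others in the source may bear on it.

Measured so far in a functional assay on MCF7 cells (Homo sapiens) for antiproliferative activity, read by MTT assay, with a stated time of 96 h; a higher number here means a weaker inhibitor, a lower number a stronger inhibitor:
- compound 1, `O=C1C2=C(C(=O)c3ncccc31)C1(CS2)NC(=O)N(c2ccccc2)C1=O`: 1 nM
- compound 2, `Cc1ccc(N2C(=O)NC3(CSC4=C3C(=O)c3ncccc3C4=O)C2=O)cc1`: 2 nM
- compound 3, `CCCCc1ccc(N2C(=O)NC3(CSC4=C3C(=O)c3ncccc3C4=O)C2=O)cc1`: 70 nM

Compound 3 gives the highest of the three numbers. The nearest is compound 2, reached by a 35-fold higher number from compound 2 to compound 3 (1.54 log units; beyond the scatter); the furthest is compound 1, reached by a 70-fold higher number from compound 1 to compound 3 (1.85 log units; beyond the scatter). Compound 1 and compound 2 lie within the scatter of each other, a 2.0-fold higher number from compound 1 to compound 2 (0.30 log units; within the scatter).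

Compound 4, `O=C1C2=C(C(=O)c3ncccc31)C1(CS2)NC(=O)N(c2ccncc2)C1=O`, is not yet measured. Its change from compound 3 is pyridin-4-yl in place of 4-butylphenyl on an amide-type nitrogen in a ring.

Among the compounds with values here, two measured steps bear on this. The step of a 70-fold higher number from compound 1 to compound 3 (1.85 log units; beyond the scatter) and the step of a 35-fold higher number from compound 2 to compound 3 (1.54 log units; beyond the scatter) both show that the butyl chain on the aromatic ring goes with a much higher number. Compound 4 carries no such chain, so a large step back toward the lower numbers of compound 1 and compound 2 is expected in this assay. Within the data shown here, no measured pair shows what pyridin-4-yl does in place of phenyl, so the range is kept wide. The expected step is a 23-fold lower number from compound 3 to compound 4 (1.37 log units; beyond the scatter). Compound 4 is estimated at 3 nM, between 0.8 nM and 15 nM.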

Compound 4, half-maximal inhibitory concentration: 10 nM
Compound 4: middle estimate off by 3.3-fold (0.52 log units), on the low side; low and high end bracket the measured number.
By their numbers in this assay, from the lowest: compounds 1 and 2 (each within the scatter of the next); then compound 4; then compound 3.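

In this assay, the aromatic ring on the amide-type nitrogen in a ring responds to a change in the ring itself, not only to a group carried on it: pyridin-4-yl in place of phenyl gives a 10-fold higher number from compound 1 to compound 4 (1.00 log units; beyond the scatter) and pyridin-4-yl in place of 4-methylphenyl gives a 5.0-fold higher number from compound 2 to compound 4 (0.70 log units; beyond the scatter) with both steps beyond the scatter. Pyridin-4-yl in place of 4-butylphenyl gives a 7.0-fold lower number from compound 3 to compound 4 (0.85 log units; beyond the scatter) so this position keeps a low nanomolar number with a hetero atom in the ring, though compound 1 and compound 2 remain lower. No measured evidence accounts for these steps.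

Still open, going by these compounds, is whether pyridin-3-yl or pyridin-2-yl would behave as pyridin-4-yl does at this nitrogen. Ethyl or propyl chains, and an amine or a carboxylic acid on the phenyl ring, also remain untested here.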